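The compounds below may be only part of what the source reports. "The series", "measured", "known", "first", "only" and "open" are said of these compounds alone.

Working notes on the series, read in an ADME assay on microsomes from liver (Homo sapiens) for metabolic stability, with a stated time of 60 min, tested at 1 uM; a higher number here means that more of the compound is left, a lower number that less of the compound is left. For the measured compounds named here, compound 1 (`COc1cc(-c2cnn3cc(OC)c(-c4cnn(C)c4)nc23)ccn1`) gives 43%, and compound 2 (`COc1cc(-c2cnn3cc(OC)c(C(C)(C)O)nc23)ccn1`) gives 66%, the higher of the two numbers so far. The next analogue, compound 3 (`COc1cc(-c2cnn3cc(OC)c(C)nc23)ccn1`), has methyl in place of 1-hydroxy-1-methylethyl on an aromatic carbon. Going by the values given here, only one measured step bears on this change, and it concerns the same aromatic carbon. That step is a number 23 percentage points higher from compound 1 to compound 2 (beyond the scatter), modest but beyond the scatter, with 1-hydroxy-1-methylethyl in place of 1-methyl-1H-pyrazol-4-yl. It shows that a change at this carbon can move the number in this assay. Among the compounds with values here, no measured compound carries methyl there, so the data do not settle the direction. A modest fall from compound 2 is expected, smaller than the measured step, and a small rise cannot be excluded. The estimated change is a number 11 percentage points lower from compound 2 to compound 3 (beyond the scatter). For compound 3 the expected value is 55%, with an estimated range of 35% to 75%.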

Compound 3, percent of the compound remaining: 44%
Compound 3: middle estimate off by 11 percentage points, on the high side; the range from low to high includes it.
By their numbers in this assay, from the lowest: compounds 1 and 3 (each within the scatter of the next); then compound 2.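

In this assay, methyl on this aromatic carbon gives a number 22 percentage points lower from compound 2 to compound 3 (beyond the scatter), so the higher number of compound 2 is not kept when 1-hydroxy-1-methylethyl leaves. For the compounds shown here, the pair that the earlier compounds could not supply shows a number 1 percentage points higher from compound 1 to compound 3 (within the scatter): methyl and 1-methyl-1H-pyrazol-4-yl cannot be told apart in this read-out, although they differ in size and only one of them carries a ring. Of the three groups at this carbon, only 1-hydroxy-1-methylethyl stands apart from the other two, and nothing in hand gives a measured reason for this.

The compounds shown leave open whether the higher number goes with the hydroxyl of 1-hydroxy-1-methylethyl or with its branched carbon skeleton, a question that a tert-butyl group and a hydroxymethyl group at the same carbon would separate. They also leave open whether the gap between compound 2 and the other two compounds would hold with a different methoxy-bearing part of the shared core.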